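The source may hold more compounds than are shown below. What is called first, only, known or untested is meant among the compounds shown, and "the series" means these compounds.

Measured so far in a functional assay on PC-3 cells (Homo sapiens) for cytotoxicity, read by WST assay, with a stated time of 72 h; a higher number here means a weaker inhibitor, a lower number a stronger inhibitor:
compound 1 `COc1ccc2c(c1C)NC(=O)C2(c1ccc(O)cc1)c1ccc(F)cc1` gives 9 nM
compound 2 `COc1ccc2c(c1C)NC(=O)C2(c1ccc(O)cc1)C1CCCC1` gives 111 nM

Compound 2 at 111 nM holds the higher of the two numbers and is the weaker inhibitor of the pair. For the measured compounds named here, the one measured step is a 12-fold higher number from compound 1 to compound 2 (1.09 log units; beyond the scatter) and it lies beyond the scatter, with cyclopentyl in place of 4-fluorophenyl on a saturated ring carbon.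

Next comes compound 3 `COc1ccc2c(c1C)NC(=O)C2(c1ccc(O)cc1)C1CCCCC1` with the change cyclohexyl in place of cyclopentyl on a saturated ring carbon at that same place: cyclohexyl in place of cyclopentyl on a saturated ring carbon, two ring bonds from the ring nitrogen. Going by the values given here, the step of a 12-fold higher number from compound 1 to compound 2 (1.09 log units; beyond the scatter) is the only evidence on this place, and it removed 4-fluorophenyl altogether, whereas here a five-membered non-aromatic ring of carbon only gives way to a six-membered one. A much smaller step is therefore expected in this assay, probably within the scatter, with a slight lean toward a lower number. Among the compounds with values here, no pair of such rings has been measured, so this direction is weakly held. The estimated step is a 1.4-fold lower number from compound 2 to compound 3 (0.14 log units; within the scatter) for now. For compound 3 the expected value is 80 nM with an estimated range from 30 nM to 220 nM in this assay.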

Compound 3, half-maximal inhibitory concentration: 28 nM
The estimate for compound 3 lay 2.9-fold (0.46 log units) above the measured number; measured number outside the range, below it.
By their numbers in this assay, from the lowest: compound 1; then compound 3; then compound 2.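

In this assay the size of a non-aromatic ring of carbon only counts at this saturated ring carbon: there is a 4.0-fold lower number from compound 2 to compound 3 (0.60 log units; beyond the scatter) and this step lies beyond the scatter, although cyclohexyl in place of cyclopentyl looked like the mildest kind of change at this place. The cost of losing 4-fluorophenyl is therefore not one fixed amount for such rings, since cyclohexyl gives a 3.1-fold higher number from compound 1 to compound 3 (0.49 log units; beyond the scatter) whereas cyclopentyl gave a 12-fold higher number from compound 1 to compound 2 (1.09 log units; beyond the scatter) and compound 1 keeps the lowest number of the three. The data on hand offer nothing that accounts for the difference between the two rings.

From the compounds shown here alone, whether the trend from cyclopentyl to cyclohexyl carries on to cycloheptyl remains open, as does whether a ring holding nitrogen such as piperidinyl, or an open chain such as n-hexyl, would fall nearer compound 3 or compound 2. All three compounds share the same core and differ only at this place, so whether the order of these groups holds with any other change to the shared core is also unknown.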